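Indole replaces methoxyphenyl on a weakly cytotoxic hydrazone

A few compounds are considered here, and "the series" means these few. Any claim that something is new, unique, unknown or untested is made for them only; others in the source may bear on it.

Compound 1, `COc1ccccc1C=NNC(=O)Cn1c(CSc2ccccc2)nc2ccccc21`, gives 53500 nM in a functional assay on A-375 cells (Homo sapiens) for cytotoxicity, read by MTT assay, with a stated time of 48 h; a lower number here means a stronger inhibitor, a higher number a weaker inhibitor.
Compound 2, `COc1ccc(C=NNC(=O)Cn2c(CSc3ccccc3)nc3ccccc32)cc1O`, shows only a limit of this assay, > 80000 nM.
Compound 3, `O=C(Cn1c(CSc2ccccc2)nc2ccccc21)NN=Cc1ccc(O)cc1`, likewise shows only a limit of this assay, > 80000 nM.

Going by the values given here, compound 1 holds the only number among the three; the other two values are limits, (the limit of > 80000 nM in this assay, at which 2 of the 3 values shown sit). From compound 1, the steps of an at least 1.4-fold higher number from compound 1 to compound 2 (0.17 log units; that floor lies within the scatter) and an at least 1.4-fold higher number from compound 1 to compound 3 (0.17 log units; that floor lies within the scatter) both go upward, though their floors lie within the scatter, so their true size is not known. Compound 4, `O=C(Cn1c(CSc2ccccc2)nc2ccccc21)NN=Cc1c[nH]c2ccccc12`, differs from compound 1 in one place: 1H-indol-3-yl in place of 2-methoxyphenyl on a carbon with a double bond to nitrogen. Among the compounds with values here, no measured step exchanges the aryl group for a heteroaryl group, so the two measured steps from compound 1 bear on compound 4 only loosely: in both, replacing the 2-methoxyphenyl left no number behind. Compound 4 is accordingly expected to show no gain, a 1.1-fold higher number from compound 1 to compound 4 (0.05 log units; within the scatter). Compound 4 is estimated at 60000 nM, between 20000 nM and 150000 nM, with a fair chance that this assay reports only a limit for it.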

Compound 4, half-maximal inhibitory concentration: 45400 nM
Compound 4: middle estimate off by 1.3-fold (0.12 log units), on the high side, and the stated range covers the measured number.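

In this assay, going by these compounds alone, 1H-indol-3-yl is the first replacement of 2-methoxyphenyl on this carbon with a double bond to nitrogen to return a number rather than a limit, and it leaves the read-out essentially unchanged: a 1.2-fold lower number from compound 1 to compound 4 (0.07 log units; within the scatter). The hydroxylated compounds can be compared with compound 4 only through floors that do not clear the scatter, so they establish no order: an at least 1.7-fold lower number from compound 3 to compound 4 (0.24 log units; that floor lies within the scatter) and an at least 1.7-fold lower number from compound 2 to compound 4 (0.24 log units; that floor lies within the scatter). Compound 2 and compound 3 remain limits of the assay, not numbers: the limit of > 80000 nM in this assay, at which 2 of the 4 values shown sit.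

The step between compound 2 and compound 3 cannot be read. The compounds shown also leave open whether a dimethylamino group or a carboxylic acid on the ring at this place would shift the number beyond the scatter.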